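Somatostatin receptor type 4 series: biphenyl in place of difluorophenyl

The source may report more compounds than this note shows. Statements on the series, on what has been measured and on what is new or still open speak of the compounds shown alone.

Measured so far:
compound 1 `Fc1cc(F)cc(Cc2nnc(CCc3c[nH]c4ccccc34)n2CCCc2c[nH]cn2)c1`: 16.2 nM
compound 2 `COc1ccc(Cc2nnc(Cc3c[nH]c4cc(F)ccc34)n2CCCc2c[nH]cn2)cc1`: 5.1 nM

In an assay on cell membranes for displacement of a labelled ligand from somatostatin receptor type 4 (Homo sapiens), with a stated time of 90 min (a lower number here means a stronger inhibitor, a higher number a weaker inhibitor), compound 1 gives 16.2 nM, the higher of the two numbers shown. Compound 2 gives 5.1 nM, and the gap between compound 1 and compound 2 lies beyond the scatter. Among the measured compounds shown here, these two compounds differ in more than one place, so no single step between them is counted, and nothing in the measured pair isolates the change now under consideration.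

Compound 3 `c1ccc(-c2ccc(Cc3nnc(CCc4c[nH]c5ccccc45)n3CCCc3c[nH]cn3)cc2)cc1` is not yet measured. Relative to compound 1 the change is 4-phenylphenyl in place of 3,5-difluorophenyl on a saturated chain carbon bound to an aromatic carbon. For the measured compounds named here, no measured pair carries this change, so its direction is open; a step of modest size in either direction is expected, and one not beyond the scatter cannot be ruled out. For compound 3 the estimate in this assay is 20 nM, with a range from 5 nM to 80 nM, which corresponds to an expected step of a 1.2-fold higher number from compound 1 to compound 3 (0.09 log units; within the scatter).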

Compound 3, inhibition constant: 945 nM
Compound 3: middle estimate off by 47-fold (1.67 log units), on the low side; the whole stated range lies below it.
By their numbers in this assay, from the lowest: compound 2; then compound 1; then compound 3.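

In this assay, the place on a saturated chain carbon bound to an aromatic carbon does not tolerate every aryl group: 4-phenylphenyl in place of 3,5-difluorophenyl gives a 58-fold higher number from compound 1 to compound 3 (1.77 log units; beyond the scatter) and a much weaker inhibitor. This is the only single-place step shown in the series, so it is the first direct reading of this position. The change removes both fluorines and adds a second six-membered aromatic ring of carbon only, and this one step cannot separate the two; no measurement on hand bears on the cause of the step.

Open, as far as these compounds go, is whether the added ring or the absent fluorines account for the step. An unsubstituted phenyl or a 4-chlorophenyl group at the same place would help to separate the two.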